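The source may hold more compounds than are shown below. What is called first, only, known or untested is meant among the compounds shown, and "the series" means these compounds.

Measured compounds in this series:

Compound 1 `NC(=O)c1c(NC(=O)c2ccccc2Cl)sc2c1CCN(C(=O)Nc1cc(C(F)(F)F)cc(C(F)(F)F)c1)C2` — 38600 nM
Compound 2 `NC(=O)c1c(NC(=O)c2ccccc2Br)sc2c1CCN(C(=S)Nc1ccccc1Cl)C2` — 46900 nM

In a functional assay on HeLa cells (Homo sapiens) for antiproliferative activity, with a stated time of 24 h (on this read-out lower numbers stand for stronger inhibition and higher numbers for weaker inhibition), compound 1 gives 38600 nM and compound 2 gives 46900 nM. Compound 2 has the higher of the two numbers, but the gap to compound 1 lies within the scatter, so the two cannot be separated on this read-out; both sit in the weak range.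

Compound 3 `NC(=O)c1c(NC(=O)c2ccncn2)sc2c1CCN(C(=S)Nc1ccccc1Cl)C2` has not been measured. Relative to compound 2 it carries pyrimidin-4-yl in place of 2-bromophenyl on a carbonyl carbon. For the measured compounds named here, no pair of measured compounds shows this kind of change, so there is no step to lean on; the only guide is that the two measured compounds give numbers close to each other. Compound 3 is therefore expected to land near compound 2, with the step of a 1.1-fold higher number from compound 2 to compound 3 (0.03 log units; within the scatter) not reaching beyond the scatter. The estimate for compound 3 in this assay is 50000 nM, within a range of 15000 nM to 150000 nM.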

Compound 3, half-maximal inhibitory concentration: > 50000 nM
Compound 3 gave a limit, no number; the forecaster's own chance of this, stated with the estimate: 30%; the middle value sits exactly at the limit.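

In this assay compound 3 gives only a limit, not a number: > 50000 nM. Pyrimidin-4-yl in place of 2-bromophenyl on a carbonyl carbon gives the first readable step in the series, an at least 1.0-fold higher number from compound 2 to compound 3 (0.02 log units; that floor lies within the scatter); this is a floor, so the true size of the step could be larger. At this position, the change from a carbon-only ring carrying bromine to a ring with two hetero atoms shows no gain in inhibition, and any loss cannot be sized: the limit of > 50000 nM in this assay, at which 1 of the 3 values shown sits.

Going by these compounds, whether the step from compound 2 to compound 3 truly exceeds the scatter remains open. Also open, on these data alone, is whether an unsubstituted phenyl, or a phenyl bearing an amine or a carboxylic acid, on this carbonyl would give a number clearly stronger than those of compound 2 and compound 3.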